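This account rests on a few compounds, and the source may have more. Where it says the series, first, only, none or still open, it means among the compounds named here.

Measured so far in a physicochemical assay for lipophilicity; a lower number here means a more polar compound, a higher number a more lipophilic compound:
- compound 1 `CN1CCN(CCCS(=O)(=O)c2ccc3nc(NC(=O)NC(=O)c4cccc(-n5cccn5)c4Cl)sc3c2)CC1`: 1.6
- compound 2 `CN1CCC(S(=O)(=O)c2ccc3nc(NC(=O)NC(=O)c4cc(-n5cccn5)ccc4Cl)sc3c2)CC1`: 2.5

Of these two, compound 1, at 1.6, has the lower number, and compound 2, at 2.5, lies higher by more than the usual scatter of repeated measurements. The two compounds differ in more than one place, so their gap cannot be tied to any single structural change.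

The next compound to be measured is compound 3 `CN1CCN(CCCS(=O)(=O)c2ccc3nc(NC(=O)NC(=O)c4cc(N5CCCC5)ccc4Cl)sc3c2)CC1`. It keeps the rest of compound 1 and changes only the group on a carbonyl carbon, where 2-chloro-5-(pyrrolidin-1-yl)phenyl stands in place of 2-chloro-3-(1H-pyrazol-1-yl)phenyl (2-chloro-5-(pyrrolidin-1-yl)phenyl in place of 2-chloro-3-(1H-pyrazol-1-yl)phenyl on a carbonyl carbon). A five-membered aromatic ring is thus exchanged for a five-membered non-aromatic ring.

Among the compounds with values here, no measured pair shows this exchange directly, so any expectation here is a judgement from the structures alone. A modest rise in this assay seems likely, and the expected change is a number 0.50 log units higher from compound 1 to compound 3 (beyond the scatter). For compound 3 the estimated value is 2.1, with an expected range from 1.5 to 2.7.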

Compound 3, distribution coefficient: 3.1
Beside the measured number, compound 3's estimate is 1.00 log units below it; measured number outside the range, above it.
By their numbers in this assay, from the lowest: compound 1; then compound 2; then compound 3.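

In this assay, replacing 2-chloro-3-(1H-pyrazol-1-yl)phenyl with 2-chloro-5-(pyrrolidin-1-yl)phenyl on a carbonyl carbon gives a number 1.50 log units higher from compound 1 to compound 3 (beyond the scatter), so a change at this position alone can shift the reading by a large amount. Both groups hold 12 heavy atoms, so the shift comes with no change in that count, though the entering group has a non-aromatic ring with 1 hetero atom where the leaving group has an aromatic ring with 2. No measurement shown here accounts for the size of this step.

The exchange also alters the number in the group's name from 3 to 5, so this one step cannot separate the change of ring from the change of where it is attached. A 2-chloro-3-(pyrrolidin-1-yl)phenyl group on the same compound would address that question, while a 2-chloro-5-(piperidin-1-yl)phenyl or 2-chloro-5-(morpholin-4-yl)phenyl group would extend the comparison to other non-aromatic rings.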